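Replacing 4-ethoxyphenyl on an amide-type nitrogen

The source may hold more compounds than are shown below. What is called first, only, known or untested is meant among the compounds shown, and "the series" means these compounds.

Compound 1 `C=CCN(C)C(=O)c1ccc(C(CC)(CC)c2ccc(OCCC(O)(CC)CC)c(C)c2)n1CC` in a functional assay on HepG2 cells (Homo sapiens) for antiproliferative activity, read by MTT assay, with a stated time of 48 h (on this read-out lower numbers stand for stronger inhibition and higher numbers for weaker inhibition), gives > 50000 nM (a limit)
Compound 2 `CCOc1ccc(NC(=O)c2ccc(C(CC)(CC)c3ccc(OCCC(O)(CC)CC)c(C)c3)n2CC)cc1` in this assay gives > 50000 nM (a limit)

Compound 2 has no numerical value on these data. In this assay compound 2 reads > 50000 nM, which is a limit and not a number. Going by the values given here, the only other reading, for compound 1, is a limit as well, and both compounds sit at the limit of > 50000 nM in this assay, at which 2 of the 2 values shown sit. Among the compounds with values here, the one measured step is a step that the two limits leave unreadable from compound 1 to compound 2, so it gives no size to carry forward.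

Compound 3 `CCC(C)C(NC(=O)c1ccc(C(CC)(CC)c2ccc(OCCC(O)(CC)CC)c(C)c2)n1CC)C(=O)O` is the next structure, with this difference from compound 2: 1-carboxy-2-methylbutyl in place of 4-ethoxyphenyl on an amide-type nitrogen. In words, 1-carboxy-2-methylbutyl stands in place of 4-ethoxyphenyl on an amide-type nitrogen. Within the data shown here, no measured step covers this exchange. The expectation therefore rests on compound 2, whose reading of > 50000 nM is a limit. No step beyond the scatter is expected in this assay, and no direction can be given. The estimated change is an at least 1.2-fold lower number from compound 2 to compound 3 (0.09 log units; that floor lies within the scatter). For compound 3 the estimate is 40000 nM, with an expected range from 12000 nM to 100000 nM.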

Compound 3, half-maximal inhibitory concentration: 2620 nM
Compound 3: the middle estimate sits 15-fold (1.18 log units) above what was measured; measured number below the stated range.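

Going by these compounds alone, on an amide-type nitrogen, the substituent proves able to bring the series from limit readings to a measured number in this assay, something the earlier compounds, whose mutual step cannot be read, did not show. Placing 1-carboxy-2-methylbutyl there instead of 4-ethoxyphenyl gives an at least 19-fold lower number from compound 2 to compound 3 (1.28 log units; beyond the scatter), and the matching exchange of allyl(methyl)amino for (1-carboxy-2-methylbutyl)amino on the carbonyl carbon gives an at least 19-fold lower number from compound 1 to compound 3 (1.28 log units; beyond the scatter). Both sizes are floors and not exact measures, because each starting compound stands at a limit: the limit of > 50000 nM in this assay, at which 2 of the 3 values shown sit.

Each exchange changes several features at once, so the compounds shown do not tell whether the step belongs to the carboxy group, to the branched chain or to the absence of the earlier substituent. As far as these compounds go, a plain 2-methylbutyl chain, a methyl ester in place of the carboxy group or a primary amine on the same chain would be needed to separate these parts, and the reading of any such compound remains open.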